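Anilide series: effect of removing the phenolic hydroxy

This account rests on a few compounds, and the source may have more. Where it says the series, first, only, none or still open, it means among the compounds named here.

Measured so far:
compound 1 `O=C(Nc1ccccc1C(F)(F)F)C1CCc2ccccc2N1`: 53300 nM
compound 2 `O=C(Nc1ccccc1O)C1CCc2ccccc2N1`: 4310 nM

In a functional assay on PC-3 cells (Homo sapiens) for cytotoxicity, read by sulforhodamine B assay, with a stated time of 72 h (on this read-out higher numbers stand for weaker inhibition of growth and lower numbers for stronger inhibition of growth), compound 1 gives 53300 nM and compound 2 gives 4310 nM. Compound 2 stands lowest of the two numbers; its nearest neighbour is compound 1, and the step of a 12-fold lower number from compound 1 to compound 2 (1.09 log units; beyond the scatter) is large and beyond the scatter.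

Compound 3 `O=C(Nc1ccccc1)C1CCc2ccccc2N1` has not yet been measured. It differs from compound 2 by hydrogen in place of hydroxy on an aromatic carbon, the hydroxy sitting on an aromatic carbon of a six-membered aromatic ring of carbon only, ortho to a large group.

Among the measured compounds shown here, only one measured step bears on this change: from compound 1 to compound 2 the exchange of trifluoromethyl for hydroxy lowered the number strongly (a 12-fold lower number from compound 1 to compound 2 (1.09 log units; beyond the scatter)). Whether the hydroxy itself carries that gain, or whether the loss of the trifluoromethyl does, cannot be separated on two compounds. Compound 3 therefore is expected to sit between the two measured numbers, with a 3.5-fold higher number from compound 2 to compound 3 (0.54 log units; beyond the scatter) in the direction of weaker inhibition of growth. That expected step is smaller than the measured step of a 12-fold lower number from compound 1 to compound 2 (1.09 log units; beyond the scatter). For compound 3 the estimate in this assay is 15000 nM, with a range from 5000 nM to 50000 nM.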

Compound 3, concentration for 50% growth inhibition: 110000 nM
Estimate against measurement, compound 3: 7.3-fold (0.87 log units) below, and the stated range ends below it.
By their numbers in this assay, from the lowest: compound 2; then compound 1; then compound 3.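

In this assay the hydroxy itself carries the gain, as hydrogen in its place gives a 26-fold higher number from compound 2 to compound 3 (1.41 log units; beyond the scatter), a larger step than the one seen when hydroxy replaced trifluoromethyl. Loss of the trifluoromethyl brings no gain of its own: hydrogen in its place gives a 2.1-fold higher number from compound 1 to compound 3 (0.31 log units; beyond the scatter), a modest step but beyond the scatter, so compound 1 retains slightly stronger inhibition of growth than compound 3 and compound 2 stands far ahead of both at this aromatic carbon. Nothing measured here accounts for the large effect of the hydroxy or for the smaller difference between trifluoromethyl and hydrogen.

The compounds shown leave open whether the gain needs the hydroxy specifically, or whether a methoxy group, an amine or a fluorine atom on this same aromatic carbon would also keep the number low. They also leave open whether a hydroxy on another carbon of the same ring would give a comparable step, and whether the gain carries over to analogues with other changes to the shared core.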